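Phenylselenyl propanamine series: removing the ring methyl

A few compounds are considered here, and "the series" means these few. Any claim that something is new, unique, unknown or untested is made for them only; others in the source may bear on it.

Two compounds of the series have been run in an assay on isolated protein for inhibition of Amine oxidase [flavin-containing] A (Homo sapiens), read by fluorescence and spectrophotometry; a lower number here means a stronger inhibitor, a higher number a weaker inhibitor. Compound 1 `CC(N)CSc1ccccc1` gives 4720 nM. Going by the values given here, compound 2 `Cc1ccc([Se]CC(C)N)cc1` gives 2030 nM, the lowest of the two numbers so far, and its gap to compound 1 lies beyond the scatter. Among the compounds with values here, no step between measured compounds that differ in one place is available, so these two values are all that the series shows at present.

Compound 3 `CC(N)C[Se]c1ccccc1` is still to be measured in this assay. It differs from compound 2 by hydrogen in place of methyl on an aromatic carbon. Compound 1 differs from compound 2 in more than one place and gives no direct guide to this change. The step expected from compound 2 to compound 3 is a 1.3-fold higher number from compound 2 to compound 3 (0.11 log units; within the scatter), small and within the scatter or only just outside it. Compound 3 is expected to give 2600 nM in this assay, with a range from 1200 nM to 5500 nM.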

Compound 3, half-maximal inhibitory concentration: 9790 nM
The estimate for compound 3 lay 3.8-fold (0.58 log units) below the measured number; the measured number lies above the stated range.
By their numbers in this assay, from the lowest: compound 2; then compound 1; then compound 3.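

Going by these compounds alone, this is the first direct reading of this position: in this assay hydrogen in place of methyl on an aromatic carbon gives a 4.8-fold higher number from compound 2 to compound 3 (0.68 log units; beyond the scatter) and so the change is not silent at this place. Compound 1 differs from compound 2 in more than one place, so the earlier values could not isolate the share of this single methyl, para to a group of 5 heavy atoms. No measured finding on hand accounts for the size of this step.

Going by these compounds, whether an ethyl group, a methoxy group or a chlorine atom at this same place would move the number further in either direction remains open. On these data alone, it is also open whether a methyl group on the ring of compound 1 would give a step of similar size.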